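The source may report more compounds than this note shows. Statements on the series, on what has been measured and on what is new or still open speak of the compounds shown alone.

The shared core appears in compound 1 `COc1cc(Cl)cc(-c2nn(-c3cccc(NC(=O)Nc4ccc(Cl)c(C(F)(F)F)c4)c3)cc2-c2ccncc2)c1` and in compound 2 `COc1cc(Cl)cc(-c2nn(-c3cccc(NC(=O)Nc4cccc(C(F)(F)F)c4)c3)cc2-c2ccncc2)c1`. In a functional assay on T47D cells (Homo sapiens) for inhibition, read by sulforhodamine B assay, with a stated time of 48 h, tested at 0.01 uM (a higher number here means a weaker effect of the compound at the concentration tested, a lower number a stronger effect), compound 1 gives 98%, and in this assay compound 2 gives 97%. Among the measured compounds shown here, the single step between measured compounds, a number 1 percentage points lower from compound 1 to compound 2 (within the scatter), puts hydrogen in place of chloro on an aromatic carbon and stays within the scatter. Compound 2 thus holds the lower of the two numbers, with compound 1 within the scatter of it, so neither can be called the stronger.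

Compound 3 `COc1cc(Cl)cc(-c2nn(-c3cccc(NC(=O)c4cccc(C(F)(F)F)c4)c3)cc2-c2ccncc2)c1` differs from compound 2 by 3-(trifluoromethyl)phenyl in place of (3-(trifluoromethyl)phenyl)amino on a carbonyl carbon; the change sits on a carbonyl carbon whose other neighbour, the amide-type nitrogen, remains. For the measured compounds named here, no measured step touches that carbonyl carbon; the one known step lies elsewhere and was within the scatter, so it offers no direction for this change. Both measured numbers in this assay lie near the top of the scale, leaving little room for a higher number.

The expected step is therefore none beyond the scatter, a number 2 percentage points lower from compound 2 to compound 3 (within the scatter), and compound 3 is estimated at 95%, within 80% to 105%.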

Compound 3, a percentage reported as activity, at one concentration (the size of the read-out at that concentration, not a potency): 99%
Compound 3: the middle estimate sits 4 percentage points below what was measured, and the stated range covers the measured number.
By their numbers in this assay, from the lowest: compounds 2, 1 and 3 (each within the scatter of the next).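

The first change measured on this carbonyl carbon, with the (3-(trifluoromethyl)phenyl)amino group and its hydrogen-bond donor giving way to 3-(trifluoromethyl)phenyl, is a step of a number 2 percentage points higher from compound 2 to compound 3 (within the scatter) in this assay and stays within the scatter. The same holds for the step of a number 1 percentage points higher from compound 1 to compound 3 (within the scatter) in which the (4-chloro-3-(trifluoromethyl)phenyl)amino group is replaced, so at this single concentration the read-out separates neither the two replacements nor the amino-linked and directly attached aryl groups, while all three numbers remain near the top of the scale, where little effect is seen and a real difference in the strength of the effect could go unseen. Nothing measured here explains this result or ties it to any property of the groups exchanged.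

Still open, going by these compounds, is whether any of the three compounds would separate from the others at a higher concentration, where the read-out would have room to fall. Also open, on these data alone, is whether a morpholine, a carboxylic acid or a short alkyl chain on the same carbonyl carbon would give a number outside the scatter of these three.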